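Adding a Second Methoxy Group on a Biaryl Amide Series

The source may report more compounds than this note shows. Statements on the series, on what has been measured and on what is new or still open speak of the compounds shown alone.

Measured compounds:
Compound 1, `COc1cccc(-c2cccc(NC(=O)CCc3cccc4c3COB4O)c2)c1`: 78000 nM
Compound 2, `COc1cc(OC)cc(-c2cccc(NC(=O)CCc3cccc4c3COB4O)c2)c1`: 88000 nM
Compound 3, `COc1cccc(-c2cccc(NC(=O)CCc3ccccc3)c2)c1`: 24000 nM

In a functional assay on SK-OV-3 cells (Homo sapiens) for antiproliferative activity, read by MTT assay, with a stated time of 72 h (a higher number here means a weaker inhibitor, a lower number a stronger inhibitor), compound 3 gives the lowest of the three numbers, 24000 nM. Compound 1 gives 78000 nM and compound 2 gives 88000 nM. The difference between the core of compound 1 and the core of compound 3 is not broken down here.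

Compound 1 and compound 2 differ in one place, (methoxy in place of hydrogen on an aromatic carbon), and this produced a 1.1-fold higher number from compound 1 to compound 2 (0.05 log units; within the scatter). Compound 4, `COc1cc(OC)cc(-c2cccc(NC(=O)CCc3ccccc3)c2)c1`, has not yet been measured. It stands to compound 3 as compound 2 stands to compound 1, the same change: methoxy in place of hydrogen on an aromatic carbon. The surroundings of the changed position read the same in both pairs.

Among the compounds with values here, the one measured instance of this change is the only basis for an expectation. Since compound 1 to compound 2 gave a 1.1-fold higher number from compound 1 to compound 2 (0.05 log units; within the scatter), compound 4 is expected to sit close to compound 3, with an estimated step of a 1.1-fold higher number from compound 3 to compound 4 (0.05 log units; within the scatter). For compound 4 the estimate is 27000 nM, with a range from 12000 nM to 60000 nM.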

Compound 4, half-maximal inhibitory concentration: > 100000 nM
Compound 4 gave a limit, no number (the forecaster's own chance of this, stated with the estimate: 5%); at least 3.7-fold (0.56 log units) between middle value and limit.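

In this assay compound 4 gives > 100000 nM, which is a limit of the assay and not a number, so the step that ends at it has only a floor: the limit of > 100000 nM in this assay, at which 1 of the 4 values shown sits. Even so, methoxy in place of hydrogen on an aromatic carbon gave an at least 4.1-fold higher number from compound 3 to compound 4 (0.61 log units; beyond the scatter), and so did not carry over from the core of compound 1 with a step of the same size: the same change on two cores in this assay, a 1.1-fold higher number (0.05 log units; within the scatter) from compound 1 to compound 2 and an at least 4.1-fold higher number (0.61 log units; beyond the scatter) from compound 3 to compound 4, at least 3.6-fold (0.56 log units) apart, beyond the scatter of two such steps. This shows that the step depended on the core in these two pairs, but it does not show the full size of the step on the core of compound 3 or the reason for the gap, and an at least 1.1-fold higher number from compound 2 to compound 4 (0.05 log units; that floor lies within the scatter) gives only a floor, which leaves the order of those two compounds unsettled.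

The compounds shown leave open whether the same dependence on the core would appear with a fluorine or a hydroxyl at the changed position. They also leave open how the two cores would compare with a longer chain leading away from the carbonyl.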